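From Compound 2 to Compound 4 on One Oxygen

The source may report more compounds than this note shows. Statements on the series, on what has been measured and on what is new or still open speak of the compounds shown alone.

Three related compounds have been measured so far. In a functional assay on HL-60 cells (Homo sapiens) for inhibition, read by CCK-8 assay, with a stated time of 48 h (on this read-out lower numbers stand for stronger inhibition and higher numbers for weaker inhibition), compound 1 `O=C(NCCNS(=O)(=O)c1ccc(-c2ccccc2O[C@H]2CC[C@H](O)CC2)s1)Nc1cc(C(F)(F)F)cc(C(F)(F)F)c1` gives 7100 nM, compound 2 `O=C(NCCNS(=O)(=O)c1ccc(-c2ccccc2OCc2cccc(O)c2)s1)Nc1cc(C(F)(F)F)cc(C(F)(F)F)c1` gives 4000 nM and compound 3 `COc1ccc(Oc2ccccc2-c2ccsc2S(=O)(=O)NCCNC(=S)Nc2cc(C(F)(F)F)cc(C(F)(F)F)c2)cc1OC` gives 2800 nM. Compound 2 holds the middle place among these three numbers, although it lies within the scatter of each of the other two.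

Compound 4 `Nc1ccc(Oc2ccccc2-c2ccc(S(=O)(=O)NCCNC(=O)Nc3cc(C(F)(F)F)cc(C(F)(F)F)c3)s2)cc1` keeps the rest of compound 2 and alters one place: 4-aminophenyl in place of 3-hydroxybenzyl on an oxygen on an aromatic ring. The group that enters sits on an oxygen on an aromatic ring.

For the measured compounds named here, one measured step bears directly on this oxygen: a 1.8-fold lower number from compound 1 to compound 2 (0.25 log units; within the scatter), which stays within the scatter. A looser guide is compound 3, whose oxygen also carries an aromatic ring, though its core differs from that of compound 2. Compound 3 gives 2800 nM. Going by the values given here, no measured compound carries the 4-aminophenyl group, and the evidence at this oxygen is thin. No change beyond the scatter is therefore expected in this assay, and a wide range is warranted.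

The expected move is a 1.3-fold lower number from compound 2 to compound 4 (0.12 log units; within the scatter), which would remain within the scatter. For compound 4 the estimated value is 3000 nM, with an expected range from 1000 nM to 9000 nM.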

Compound 4, half-maximal inhibitory concentration: > 50000 nM
Compound 4: a limit, no number (the forecaster's own chance of this, stated with the estimate: 5%); middle value at least 16-fold (1.22 log units) away from the limit.
By their numbers in this assay, from the lowest: compounds 3, 2 and 1 (each within the scatter of the next, the first and the last beyond it). At a limit, above all of these: compound 4.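

Compound 4 in this assay is recorded as a limit and not as a number: the limit of > 50000 nM in this assay, at which 1 of the 4 values shown sits. The earlier compounds had shown only a move within the scatter at this oxygen, whereas 4-aminophenyl in place of 3-hydroxybenzyl gives an at least 12-fold higher number from compound 2 to compound 4 (1.09 log units; beyond the scatter), and 4-aminophenyl in place of 4-hydroxycyclohexyl gives an at least 7.0-fold higher number from compound 1 to compound 4 (0.84 log units; beyond the scatter). The oxygen is therefore not indifferent to what it carries in this assay, and the counts do not separate the two groups in the first of these steps, since 3-hydroxybenzyl and 4-aminophenyl have the same numbers of hydrogen-bond donors and acceptors, one six-membered aromatic ring each and no net charge.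

The change from (3-hydroxybenzyl)oxy to 4-aminophenoxy alters two things at once, the carbon link to the ring and the hydroxyl exchanged for an amine, and the compounds shown cannot tell which of them goes with the loss. A phenyl ring carrying a hydroxyl on this oxygen, or a benzyl group carrying an amine, would pull these two apart.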